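Swapping Bromo for Carboxy on a Vinyl Amide

A few compounds are considered here, and "the series" means these few. Any claim that something is new, unique, unknown or untested is made for them only; others in the source may bear on it.

Compound 1: `CC(C)C/C(=C\C(=O)Nc1ccc2c(c1)OCCO2)c1ccc(C(C)(C)C)cc1` gives 94 nM
Compound 2: `CC(C)(C)c1ccc(/C=C/C(=O)Nc2ccc3c(c2)OCCO3)c(Br)c1` gives 470 nM

Both compounds were tested in a functional assay on CHO cells for inhibition of transient receptor potential cation channel subfamily V member 1 (Homo sapiens); on this read-out higher numbers stand for weaker inhibition and lower numbers for stronger inhibition. Of the two numbers shown, compound 2 has the higher one, meaning the weaker inhibition, and its gap to compound 1 lies beyond the usual scatter of this assay. Compound 3, `CC(C)(C)c1ccc(/C=C/C(=O)Nc2ccc3c(c2)OCCO3)c(C(=O)O)c1`, has not been measured yet. It differs from compound 2 in a single place: carboxy in place of bromo on an aromatic carbon. Within the data shown here, no pair of measured compounds covers an exchange of this kind, so the expectation rests on nothing closer than the two values above and on the nature of the change itself. A step of roughly a 4.3-fold higher number from compound 2 to compound 3 (0.63 log units; beyond the scatter) toward weaker inhibition is expected, with considerable uncertainty about its size. Compound 3 is therefore estimated to give about 2000 nM, within a range from 500 nM to 8000 nM.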

Compound 3, half-maximal inhibitory concentration: > 4000 nM
Compound 3: a limit, no number; the forecaster's own chance of this, stated with the estimate: 15%; at least 2.0-fold (0.30 log units) between middle value and limit.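

In this assay, compound 3 gives > 4000 nM, which is a limit of the assay and not a number. Carboxy in place of bromo on this aromatic carbon, ortho to a large group and meta to a tert-butyl group, brings an at least 8.5-fold higher number from compound 2 to compound 3 (0.92 log units; beyond the scatter), the first reading of a single change at this position, and it shows that the group placed here matters for inhibition. The full size of the step stays unread, and only its lower bound is known: the limit of > 4000 nM in this assay, at which 1 of the 3 values shown sits.

The compounds shown leave open whether a methyl ester, a primary amide or a chlorine atom at this position would keep the inhibition seen with compound 2 or lose it as compound 3 does. They also leave open how the same core behaves with only a hydrogen there.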